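Turning the Ring Stereocentre of Compound 2 Around

The source may hold more compounds than are shown below. What is called first, only, known or untested is meant among the compounds shown, and "the series" means these compounds.

Three compounds have been measured in an assay for inhibition of Indoleamine 2,3-dioxygenase 1 (Homo sapiens), with stated times of 10 min and 60 min; a lower number here means a stronger inhibitor, a higher number a weaker inhibitor:

Compound 1 `O=[N+]([O-])c1ccc(CNc2cc(C(F)(F)F)cc3[nH]ncc23)cc1`: 61000 nM
Compound 2 `FC(F)(F)c1cc(NC[C@H]2CCCCN2)c2cn[nH]c2c1`: 24000 nM
Compound 3 `CS(=O)(=O)c1ccc(CNc2cc(C(F)(F)F)cc3[nH]ncc23)c([N+](=O)O)c1`: 58000 nM

Compound 2 gives the lowest number of the three, and its gaps to compound 3 and to compound 1 both exceed the usual scatter, so within this small set compound 2 is the strongest inhibitor, though all three are weak.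

Compound 4 `FC(F)(F)c1cc(NC[C@@H]2CCCCN2)c2cn[nH]c2c1` is its mirror-image partner: the two compounds have the same atoms and bonds and differ only in configuration as drawn: 1 of 1 stereo elements differ; a stereocentre at a saturated ring carbon is drawn R in compound 2 and S in compound 4. For the measured compounds named here, no measured pair in this set differs only in configuration, so there is no precedent for the size of such a step. Two mirror images usually differ, and the drawn form of compound 2 is the one that has already shown the better number, so a modest loss is expected, a 1.7-fold higher number from compound 2 to compound 4 (0.22 log units; within the scatter). Compound 4 is therefore estimated at 40000 nM, with a likely range of 12000 nM to 130000 nM.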

Compound 4, half-maximal inhibitory concentration: 18700 nM
Estimate against measurement, compound 4: 2.1-fold (0.33 log units) above, within the range that was stated.
By their numbers in this assay, from the lowest: compounds 4 and 2 (each within the scatter of the next); then compounds 3 and 1 (each within the scatter of the next).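

Changing the stereocentre at the saturated ring carbon from R to S gives a 1.3-fold lower number from compound 2 to compound 4 (0.11 log units; within the scatter) in this assay, so the two mirror images cannot be told apart in this assay. For the compounds shown here, this is the first step in the set that can be read, and it tests configuration alone: the fact that compounds 2 and 4 differ only in the configuration as drawn. At this carbon, then, the drawn configuration does not set the number.

On these data alone, whether a methyl group on the ring nitrogen or a carboxylic acid on the saturated ring would shift the number remains open. So does whether configuration would matter with such a group present.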